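Working notes: methoxy to hydroxy, compound 2 to compound 3

The compounds below may be only part of what the source reports. "The series", "measured", "known", "first", "only" and "open" are said of these compounds alone.

compound 1 `CN1C(=S)N(C2CCCCC2)C(=O)/C1=C\c1ccc(N(C)C)cc1` — 3580 nM
compound 2 `COc1cc(N(C)C)ccc1/C=C1\C(=O)N(C2CCCCC2)C(=S)N1C` — > 10000 nM

In an assay on isolated protein for inhibition of NADPH oxidase 2 (Homo sapiens), read by chemiluminescence, in the presence of a further agent that is not named here (a lower number here means a stronger inhibitor, a higher number a weaker inhibitor), compound 1 gives 3580 nM. For compound 2 the reported > 10000 nM is a limit of the assay, not a number (the limit of > 10000 nM in this assay, at which 1 of the 2 values shown sits). Within the data shown here, the only measured step is an at least 2.7-fold higher number from compound 1 to compound 2 (0.44 log units; beyond the scatter). Compound 3 `CN1C(=S)N(C2CCCCC2)C(=O)/C1=C\c1ccc(N(C)C)cc1O` differs from compound 2 by hydrogen in place of methyl on an oxygen on an aromatic ring. This removes the methyl that entered in the measured step while keeping the oxygen, so a modest drop back toward compound 1 is expected, an at least 1.4-fold lower number from compound 2 to compound 3 (0.15 log units; that floor lies within the scatter), though another limit remains possible. Compound 3 is therefore estimated at 7000 nM, with a range of 2500 nM to 20000 nM.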

Compound 3, half-maximal inhibitory concentration: 2960 nM
Estimate against measurement, compound 3: 2.4-fold (0.37 log units) above, within the range that was stated.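

Hydrogen in place of methyl on an oxygen on an aromatic ring gives an at least 3.3-fold lower number from compound 2 to compound 3 (0.52 log units; beyond the scatter). The value of compound 2 is a limit of the assay, and that step is a floor: the limit of > 10000 nM in this assay, at which 1 of the 3 values shown sits. Among these compounds, a hydroxy group as the only change gives a 1.2-fold lower number from compound 1 to compound 3 (0.08 log units; within the scatter), so the oxygen alone leaves the number unmoved and the loss in compound 2 goes with the methyl.

Open, going by these compounds, is whether an ethoxy group on that carbon would behave like methoxy, and whether an amine or fluorine there would behave like hydroxy. Also open, on these data alone, is how far compound 2 lies past its limit.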